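Unbranched thiophenylmethyl amide tested against an inactive parent

This account rests on a few compounds, and the source may have more. Where it says the series, first, only, none or still open, it means among the compounds named here.

This account follows compound 1, `CCN(C(=O)COc1ccc(C)cc1)C(C)c1cccs1`, into compound 3, `CCN(Cc1ccsc1)C(=O)COc1ccc(C)cc1`. In an assay on HEK293 cells for agonist activity at transient receptor potential cation channel subfamily M member 8 (Homo sapiens), read by fluorescence and calcium flux, with a stated time of 15 min (a higher number here means that more compound is needed for the effect, a lower number that less compound is needed), compound 1 is reported as "not active" (no number reported), so it stands without a single number on the potency scale. Going by the values given here, a related compound 2, `CCN(Cc1cccs1)C(=O)C(C)Oc1ccc(C)cc1`, which carries the methyl on the chain beside the carbonyl rather than on the nitrogen substituent, gives in this assay a value of 889 nM; no step between these two is given, and the two results show only that one is measurable and the other is not. The change from compound 1 to compound 3 is (thiophen-3-yl)methyl in place of 1-(thiophen-2-yl)ethyl on an amide-type nitrogen. Among the compounds with values here, with no measured step to lean on, the size of the move in this assay cannot be read from the data; the expectation is that compound 3 will move from the unmeasurable state of compound 1 into the measurable range, since compound 2 with its own unbranched thiophenylmethyl group reaches 889 nM. Compound 3 is accordingly expected to give about 3000 nM, within a range of 800 nM to 15000 nM.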

Compound 3, half-maximal effective concentration: 88 nM
Estimate against measurement, compound 3: 34-fold (1.53 log units) above; measured number below the stated range.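

In this assay, going by these compounds alone, compound 3 gives 88 nM but compound 1 carries no single number, and no step between compound 1 and compound 3 can be read. The compounds shown leave open whether losing the branch of 1-(thiophen-2-yl)ethyl or the change to the thiophen-3-yl ring attachment matters more. No measured evidence bears on this result.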